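Fluoro in place of hydrogen on compound 2

A few compounds are considered here, and "the series" means these few. Any claim that something is new, unique, unknown or untested is made for them only; others in the source may bear on it.

In a functional assay (aorta) with Rattus norvegicus as the target (a higher number here means that more compound is needed for the effect, a lower number that less compound is needed), compound 1 (`C/N=C(/S)C1=CC(C)(CF)Oc2ccc([N+](=O)[O-])cc21`) gives 1.62 nM and compound 2 (`CC1(C)C=C(/C(S)=N\CCC#N)c2cc([N+](=O)[O-])ccc2O1`) gives 0.372 nM as the lower of the two numbers, a gap beyond the scatter. Compound 3 (`CC1(CF)C=C(/C(S)=N\CCC#N)c2cc([N+](=O)[O-])ccc2O1`) differs from compound 2 by one change: fluoro in place of hydrogen on a saturated chain carbon bound to a saturated ring carbon as fluoro in place of hydrogen on a saturated chain carbon bound to a saturated ring carbon, which reads methyl to fluoromethyl. Within the data shown here, no measured pair shows this change alone, so the expectation in this assay is no step beyond the scatter, in either direction. The estimated step is a 1.2-fold higher number from compound 2 to compound 3 (0.08 log units; within the scatter) and stays inside that scatter. For compound 3 the expected value is 0.45 nM with an estimated range from 0.15 nM to 1.4 nM at this stage.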

Compound 3, half-maximal effective concentration: 1.86 nM
Estimate against measurement, compound 3: 4.1-fold (0.62 log units) below, and the stated range ends below it.
By their numbers in this assay, from the lowest: compound 2; then compounds 1 and 3 (each within the scatter of the next).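

In this assay, among these compounds, methyl to fluoromethyl on a saturated chain carbon bound to a saturated ring carbon is the first single change read at this position, and it gives a 5.0-fold higher number from compound 2 to compound 3 (0.70 log units; beyond the scatter) in the cyanoethyl-bearing pair. With fluoromethyl held in place, cyanomethyl in place of hydrogen on a saturated chain carbon bound to a double-bonded nitrogen gives a 1.1-fold higher number from compound 1 to compound 3 (0.06 log units; within the scatter) and so separates nothing. No evidence on hand bears on the origin of the step.

Still open, going by these compounds, is whether hydroxymethyl, difluoromethyl or ethyl at this position gives a similar step. Also open, on these data alone, is whether the cyanomethyl change stays equally flat with methyl in place of fluoromethyl.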